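The source may report more compounds than this note shows. Statements on the series, on what has been measured and on what is new or still open speak of the compounds shown alone.

Compound 1, `Nc1ccc(-c2ccc3ncc(-c4noc(C(F)(F)F)n4)cc3c2)cn1`: in a functional assay on RD cells (Homo sapiens) for inhibition, read by luminescence and ATP content, with a stated time of 72 h (on this read-out higher numbers stand for lower toxicity in this test and lower numbers for higher toxicity in this test), compound 1 gives > 2500 nM, a limit of the assay.
Compound 2, `FC(F)(F)c1nc(-c2cnc3ccc(-c4ccccc4)cc3c2)no1`: in this assay compound 2 gives > 22200 nM, likewise a limit.
Compound 3, `CC(C)c1ccc(-c2ccc3ncc(-c4noc(C(F)(F)F)n4)cc3c2)cc1`: in this assay compound 3 gives > 200000 nM, again a limit.

Within the data shown here, compound 3 stands at the highest of the three limits (the limit of > 200000 nM in this assay, at which 1 of the 3 values shown sits); the other two values are limits too, so no compound has a number. The steps a step that the two limits leave unreadable from compound 1 to compound 3 and a step that the two limits leave unreadable from compound 2 to compound 3 stay unreadable, as does a step that the two limits leave unreadable from compound 1 to compound 2. Compound 4, `Fc1ccc(-c2ccc3ncc(-c4noc(C(F)(F)F)n4)cc3c2)cc1`, differs from compound 3 by fluoro in place of isopropyl on an aromatic carbon. With no readable step to lean on, no direction can be set, and the estimated step of an at least 2.0-fold lower number from compound 3 to compound 4 (0.30 log units; that floor lies within the scatter) is expected to stay within the scatter. Compound 4 is expected at 100000 nM, between 20000 nM and 300000 nM, most likely reported as a limit.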

Compound 4, half-maximal cytotoxic concentration: > 7400 nM
Compound 4 ended at the assay's limit; the forecaster's own chance of this, stated with the estimate: 75%; the middle value does not contradict the limit.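

Among these compounds, compound 4 stands at a limit, as do compound 1, compound 2 and compound 3, so no step to compound 4 can be read. Going by these compounds, whether these four compounds differ at all in this assay stays open.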